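Hydroxamate to hydrazide on the pyrrolyl acrylamide series

This account rests on a few compounds, and the source may have more. Where it says the series, first, only, none or still open, it means among the compounds named here.

Compound 2 `Cn1cc(C(=O)c2ccccc2)cc1/C=C/C(=O)NCCO` gives the lowest of the two numbers measured in an assay on isolated protein for inhibition of histone deacetylase HD2 (Zea mays), tested at 30 uM (a lower number here means less inhibition, a higher number more inhibition at the concentration tested (going by the name of the read-out)), at 0.9%; compound 1 `Cn1cc(C(=O)c2ccccc2)cc1/C=C/C(=O)NO` gives 86%. Within the data shown here, the only measured step, a number 85.1 percentage points lower from compound 1 to compound 2 (beyond the scatter), shows that enlarging the substituent on the amide-type nitrogen from hydroxy to 2-hydroxyethyl removes nearly all inhibition. The unmeasured compound 3 `Cn1cc(C(=O)c2ccccc2)cc1/C=C/C(=O)NN` carries amino in place of 2-hydroxyethyl on an amide-type nitrogen. The step of a number 85.1 percentage points lower from compound 1 to compound 2 (beyond the scatter) tied the loss to a larger group on the amide-type nitrogen. The entering amino group, like the hydroxy of compound 1, is a single heavy atom bearing one donor and one acceptor, so the change from compound 2 to compound 3 reverses that size change. Among the measured compounds shown here, a step back upward is therefore expected in this assay, though no measured pair shows whether amino matches hydroxy, so the expected recovery is partial and uncertain: a number 34.1 percentage points higher from compound 2 to compound 3 (beyond the scatter). Compound 3 is estimated at 35%, with a range from 3% to 80%.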

Compound 3, a percentage reported as inhibition, at one concentration (the size of the read-out at that concentration, not a potency): 0.2%
Compound 3: the middle estimate sits 34.8 percentage points above what was measured; the measured number lies below the stated range.
By their numbers in this assay, from the lowest: compounds 3 and 2 (each within the scatter of the next); then compound 1.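

Amino in place of 2-hydroxyethyl on the amide-type nitrogen gives a number 0.7 percentage points lower from compound 2 to compound 3 (within the scatter) in this assay, so the shorter group does not by itself bring inhibition back. Amino in place of hydroxy gives a number 85.8 percentage points lower from compound 1 to compound 3 (beyond the scatter), so the two groups are not interchangeable at this position, and among the three groups shown, only hydroxy goes with high inhibition. Nothing available explains the difference between hydroxy and amino at this position.

Left open is how methoxy or a plain methyl on the amide-type nitrogen would read in this assay, which would separate the contribution of the oxygen from that of its hydrogen. Also open, as far as these compounds go, is how a carboxylic acid in place of the whole hydroxamic acid would compare with compound 1 on the shared core.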